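Ethyl to Isopropyl at the Ester of Compound 1

A few compounds are considered here, and "the series" means these few. Any claim that something is new, unique, unknown or untested is made for them only; others in the source may bear on it.

Of the compounds shown here, three sharing one core have so far been measured in a functional assay on the whole organism (strain Sprague-Dawley CD) for inhibition, with Rattus norvegicus as the target, read by paw edema, at a dose of 30 mg/kg by the intraperitoneal route; a higher number here means a stronger effect of the compound at the dose given, a lower number a weaker effect. Compound 1, `CCOC(=O)C(=O)Nc1cccccc1=O`, gives 84% and stands highest of the three. Compound 2, `CCOC(=O)C(=O)Nc1ccccc(Oc2ccccc2)c1=O`, gives 16%, and compound 3, `CCOC(=O)C(=O)Nc1ccc(OC)ccc1=O`, gives 8%. Both measured steps start from compound 1 and place a group on an aromatic carbon: a number 68 percentage points lower from compound 1 to compound 2 (beyond the scatter) and a number 76 percentage points lower from compound 1 to compound 3 (beyond the scatter). Both are large, both point downward, and both leave the ester untouched.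

Compound 4, `CC(C)OC(=O)C(=O)Nc1cccccc1=O`, differs from compound 1 in a different place: methyl in place of hydrogen on a saturated chain carbon bound to an oxygen next to a carbonyl group and a saturated chain carbon. Neither measured step concerns the ester, so neither bears directly on this change. The two steps only show that compound 1 sits at the top of the numbers seen and that additions on the aromatic carbons cost a great deal. Within the data shown here, no measured pair shows what branching the ester alkyl does. With nothing to indicate a shift, the estimated step of a number 8 percentage points lower from compound 1 to compound 4 (within the scatter) is expected to fall within the scatter rather than beyond it. Compound 4 is therefore estimated at 76% in this assay, within an expected range from 50% to 92%.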

Compound 4, a percentage reported as inhibition, in the whole organism at one dose (the size of the read-out at that dose, not a potency): 96%
For compound 4 the middle estimate is 20 percentage points below the measured one; the whole stated range lies below it.
By their numbers in this assay, from the lowest: compounds 3 and 2 (each within the scatter of the next); then compound 1; then compound 4.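

Among these compounds, at the ester, the change from ethyl to isopropyl moves the read-out in this assay upward, a number 12 percentage points higher from compound 1 to compound 4 (beyond the scatter), and this is the first measured change on this core to raise the number. The two changes on the aromatic carbons both lowered it (a number 68 percentage points lower from compound 1 to compound 2 (beyond the scatter) and a number 76 percentage points lower from compound 1 to compound 3 (beyond the scatter)), so the modest rise at the ester shows that this position behaves differently and that compound 1, at 84%, does not mark the top of what this core can give. No measurement at hand explains why the added methyl raises the number.

As far as these compounds go, whether a longer chain, a tert-butyl group, a benzyl group or the free carboxylic acid at the ester would raise the number further, hold it or lose it remains open. Also open is whether isopropyl would give any rise on a core carrying phenoxy or methoxy on an aromatic carbon, since the compounds shown pair it only with the unsubstituted core of compound 1 and at a single dose.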